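Triazole to Tetrazole on a Thiazolylidene Hydrazide Core

The source may hold more compounds than are shown below. What is called first, only, known or untested is meant among the compounds shown, and "the series" means these compounds.

Compound 1 `Cn1cnnc1SCC(=O)N/N=c1/scc(-c2ccc(C#N)cc2)n1-c1ccccc1`: 62.6%
Compound 2 `O=C(CSc1nnnn1-c1ccccc1)N/N=c1/scc(-c2ccc(Cl)cc2)n1-c1ccccc1`: 69.3%
Compound 3 `Cc1ccc(-c2cs/c(=N/NC(=O)CSc3ncccn3)n2-c2ccccc2)cc1`: 83%

Of the compounds shown here, three sharing a hydrazide-linked thiazolylidene core have been tested in a functional assay on C6 cells (Rattus norvegicus) for cytotoxicity, read by MTT assay, with a stated time of 24 h, tested at 12 ug/mL; a higher number here means a weaker effect of the compound at the concentration tested, a lower number a stronger effect. Compound 1 gives 62.6%, the lowest of the three numbers, but its gap to compound 2, which gives 69.3%, lies within the usual scatter of such measurements, so the two cannot be told apart. Compound 3, with 83%, stands beyond the scatter from compound 1. No two of these compounds differ in a single place, so no step between measured compounds can be read off.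

Going by the values given here, compound 4 `Cn1nnnc1SCC(=O)N/N=c1/scc(-c2ccc(C#N)cc2)n1-c1ccccc1` is the one compound not yet measured. It differs from compound 1 only in one spot: 1-methyl-1H-tetrazol-5-yl in place of 4-methyl-4H-1,2,4-triazol-3-yl on a sulfur. The rest of the molecule is unchanged.

Among the compounds with values here, nothing among the measured compounds shows how this exchange of one small heteroaromatic ring for another bears on the read-out. With that in mind, the step from compound 1 to compound 4 is expected to be small, a number 1.4 percentage points higher from compound 1 to compound 4 (within the scatter), and not beyond the scatter in either direction. Compound 4 is therefore estimated to give about 64% in this assay, with a range from 48% to 80%.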

Compound 4, a percentage reported as activity, at one concentration (the size of the read-out at that concentration, not a potency): 53.9%
The estimate for compound 4 lay 10.1 percentage points above the measured number, within the range that was stated.
By their numbers in this assay, from the lowest: compounds 4, 1 and 2 (each within the scatter of the next, the first and the last beyond it); then compound 3.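

In this assay the exchange of 4-methyl-4H-1,2,4-triazol-3-yl for 1-methyl-1H-tetrazol-5-yl on a sulfur gives a number 8.7 percentage points lower from compound 1 to compound 4 (within the scatter) and this step stays within the scatter, so compound 1 and compound 4 cannot be told apart. The earlier compounds shown here differed from each other in more than one place and offered no reading at this position; this pair shows that, with the rest of the molecule unchanged, one five-membered aromatic ring with 3 hetero atoms can give way to one with 4 hetero atoms, with the same number of heavy atoms, without a step beyond the scatter. Nothing measured here offers an explanation for the size of this step.

As far as these compounds go, what remains open is whether a group of a different kind on this sulfur, such as a plain methyl, a longer chain ending in an amine, or a carboxylic acid, would produce a step beyond the scatter. From the compounds shown here alone, it is also open whether the same exchange of rings would give a similarly small step with a chlorine or a methyl in place of the nitrile, and the read-out at one concentration says nothing of potency.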